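A few compounds are considered here, and "the series" means these few. Any claim that something is new, unique, unknown or untested is made for them only; others in the source may bear on it.

Three ureas have so far been measured in an ADME assay on the whole organism with Oryza sativa as the target, tested at 0.1 uM; on this read-out lower numbers stand for a stronger effect and higher numbers for a weaker effect at the one concentration tested. Compound 1 `CCc1ccc(NC(=O)N[C@@H](C)c2ccccc2)cc1` gives 99%. Compound 2 `CCOC(=O)c1cccc(NC(=O)N[C@H](C)c2ccccc2)c1` gives 99%, and compound 3 `CCOC(=O)c1cccc(NC(=O)N[C@@H](C)c2ccccc2)c1` gives 100%, so compound 3 sits within the scatter of both of the others. The step of a number 1 percentage points higher from compound 2 to compound 3 (within the scatter) rests on (the fact that compounds 2 and 3 differ only in the configuration as drawn), and the configuration at the chain carbon thus leaves this assay unmoved. Compound 4 `C[C@H](NC(=O)Nc1cccc(Br)c1)c1ccccc1` differs from compound 3 by bromo in place of ethoxycarbonyl on an aromatic carbon. Going by the values given here, no measured step bears on this change; the only step seen, a number 1 percentage points higher from compound 2 to compound 3 (within the scatter), concerned configuration alone and stayed within the scatter. With every measured number near the top of the scale, compound 4 is expected to remain there, a step of a number 2 percentage points lower from compound 3 to compound 4 (within the scatter). Compound 4 is estimated at 98%, in a range from 85% to 100%.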

Compound 4, a percentage reported as activity, at one concentration (the size of the read-out at that concentration, not a potency): 100%
Compound 4: the middle estimate sits 2 percentage points below what was measured; low and high end bracket the measured number.
By their numbers in this assay, from the lowest: compounds 1, 2, 3 and 4 (each within the scatter of the next).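

Replacing ethoxycarbonyl with bromo on this aromatic carbon, meta to a large group, gives no change at the digits printed from compound 3 to compound 4 (within the scatter) in this assay. At this place, then, the read-out does not separate an ester carrying hydrogen-bond acceptors from a lone bromine atom, so the change extends the flat picture from configuration to the ring substituent. Nothing at hand accounts for this result. Going by these compounds, whether an amine, a carboxylic acid or a longer chain at this place would lower the number remains open. So does whether any compound in this series departs from the top of the scale.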